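This account rests on a few compounds, and the source may have more. Where it says the series, first, only, none or still open, it means among the compounds named here.

Going by the values given here, compound 1 `COc1cc2c(Oc3ccc(NC(=O)c4nnn(-c5ccc(F)cc5)c4C(F)(F)F)cc3F)ccnc2cc1OCCCN1CCCC1` gives 120 nM in a functional assay on HT-29 cells (Homo sapiens) for cytotoxicity, read by MTT assay, with a stated time of 72 h (a lower number here means a stronger inhibitor, a higher number a weaker inhibitor), the lowest of the three numbers so far, with compound 3 nearest and compound 2 furthest. Compound 2 `COc1cc2c(Oc3ccc(NC(=O)c4nnn(-c5ccc(C)cc5)c4C(F)(F)F)cc3F)ccnc2cc1OCCCN1CCCC1` gives 550 nM in this assay, and compound 3 `COc1cc2c(Oc3ccc(NC(=O)c4nnn(-c5ccccc5C(F)(F)F)c4C(F)(F)F)cc3F)ccnc2cc1OCCCN1CCCC1` gives 210 nM. The measured steps all vary the aryl on an aromatic nitrogen: a 4.6-fold higher number from compound 1 to compound 2 (0.66 log units; beyond the scatter), a 1.8-fold higher number from compound 1 to compound 3 (0.24 log units; within the scatter) and a 2.6-fold lower number from compound 2 to compound 3 (0.42 log units; beyond the scatter). Compound 4 `COc1cc2c(Oc3ccc(NC(=O)c4nnn(-c5ccc(F)cc5)c4C(F)(F)F)cc3F)ccnc2cc1OCCCN1CCCCC1` differs from compound 1 by piperidin-1-yl in place of pyrrolidin-1-yl on a saturated chain carbon, three bonds along the chain from an oxygen on an aromatic ring. Among the compounds with values here, no measured step touches this end of the molecule, so the series gives no direct guide; with only one ring carbon added, the expected step is a 1.3-fold higher number from compound 1 to compound 4 (0.10 log units; within the scatter), not beyond the scatter. Compound 4 is therefore estimated at 150 nM in this assay, within a range of 60 nM to 400 nM.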

Compound 4, half-maximal inhibitory concentration: 150 nM
For compound 4 middle estimate and measured number coincide at the digits printed, and the stated range covers the measured number.
By their numbers in this assay, from the lowest: compounds 1, 4 and 3 (each within the scatter of the next); then compound 2.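

The change at this end of the molecule, piperidin-1-yl in place of pyrrolidin-1-yl, gives a 1.3-fold higher number from compound 1 to compound 4 (0.10 log units; within the scatter) in this assay and so stays inside the scatter, whereas the aryl change gives a 4.6-fold higher number from compound 1 to compound 2 (0.66 log units; beyond the scatter) and lies beyond it. For this one pair, the added ring carbon does not separate the two compounds. No available measurement bears on why the two rings read alike.

As far as these compounds go, whether the step holds with the 4-methylphenyl group of compound 2 remains open. So does the effect of a morpholine ring or a dimethylamino group in place of these rings.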